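The source may hold more compounds than are shown below. What is called first, only, known or untested is meant among the compounds shown, and "the series" means these compounds.

Measured so far in a functional assay on MKN-45 cells (Homo sapiens) for antiproliferative activity, tested at 1 uM; a higher number here means more inhibition at the concentration tested (going by the name of the read-out), a lower number less inhibition:

- compound 1, `COc1ccc(CO/N=C/c2c(C)nn(C)c2Oc2ccc(Cl)cc2)cc1`: 28.1%
- compound 2, `Cc1c(CO/N=C/c2c(-c3ccccc3)nn(-c3ccccc3)c2Oc2ccc(Cl)cc2)cccc1-c1ccccc1`: -15%
- compound 3, `Cc1nn(C)c(Oc2ccccc2)c1/C=N/OCc1ccc(C(F)(F)F)cc1`: 11%

Compound 1 stands highest of the three numbers. The nearest is compound 3, whose inhibition is lower by a margin beyond the scatter, and the furthest is compound 2, lower still, also beyond the scatter. Among the compounds with values here, compounds 2 and 3 each differ from compound 1 in more than one place, so no single-change step between measured compounds is available; their values show only that the shared core with the substituents of compound 1 gives the most inhibition seen here.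

Compound 4 is `COC(=O)c1ccc(CO/N=C/c2c(C)nn(C)c2Oc2ccc(Cl)cc2)cc1`. It differs from compound 1 by methoxycarbonyl in place of methoxy on an aromatic carbon. Within the data shown here, no measured pair isolates a change at this position, so the direction of the step rests on compound 1 alone. With 28.1% for compound 1 as the only anchor, the step in this assay from compound 1 to compound 4 is expected to be small, either none beyond the scatter or a modest drop, a number 6.1 percentage points lower from compound 1 to compound 4 (within the scatter). Compound 4 is therefore estimated at 22%, within a range of 5% to 40%.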

Compound 4, a percentage reported as inhibition, at one concentration (the size of the read-out at that concentration, not a potency): 26.1%
Compound 4: middle estimate off by 4.1 percentage points, on the low side; the measured number falls inside the stated range.
By their numbers in this assay, from the lowest: compound 2; then compound 3; then compounds 4 and 1 (each within the scatter of the next).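

In this assay, within the data shown here, methoxycarbonyl in place of methoxy gives the first single-change step, a number 2 percentage points lower from compound 1 to compound 4 (within the scatter), so the two groups cannot be told apart at this aromatic carbon, para to a large group. Methoxycarbonyl brings 4 heavy atoms, 2 hydrogen-bond acceptors and a double bond outside the aromatic rings, against 2 heavy atoms and 1 hydrogen-bond acceptor for methoxy, and in this pair these additions leave the read-out within the scatter, which compound 2 and compound 3 could not show because each differs from compound 1 in more than one place. No measurement is available here that would explain why the two compounds read alike.

Among these compounds, open is whether a carboxylic acid, a primary amine or a longer ester such as butoxycarbonyl at this same position would also stay within the scatter of compound 1, as only two groups have been compared here. Also open, on these data alone, is whether the pair would still read alike at other concentrations, as the step rests on a single tested concentration and does not describe potency.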